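The source may hold more compounds than are shown below. What is called first, only, known or untested is meant among the compounds shown, and "the series" means these compounds.

Measured so far in a functional assay on PC-3 cells (Homo sapiens) for cytotoxicity, read by sulforhodamine B assay, with a stated time of 72 h; on this read-out lower numbers stand for stronger inhibition of growth and higher numbers for weaker inhibition of growth:
compound 1 `CCCC(=O)N1c2ccccc2CCC1C(=O)Nc1cc(C(F)(F)F)cc(C(F)(F)F)c1` gives 18600 nM;
compound 2 `O=C(Nc1cc(C(F)(F)F)cc(C(F)(F)F)c1)C1CCc2ccccc2N1C(=O)c1ccc(Cl)cc1` gives 4230 nM;
compound 3 `CCCCCCCCC(=O)N1c2ccccc2CCC1C(=O)Nc1cc(C(F)(F)F)cc(C(F)(F)F)c1` gives 7430 nM.

Compound 3 sits second highest of the three numbers. Its nearest neighbour is compound 2, with a 1.8-fold higher number from compound 2 to compound 3 (0.24 log units; within the scatter), which is within the scatter; the furthest is compound 1, with a 2.5-fold lower number from compound 1 to compound 3 (0.40 log units; beyond the scatter), which lies beyond it. Of the other measured step, a 4.4-fold lower number from compound 1 to compound 2 (0.64 log units; beyond the scatter), concerns a different change on the carbonyl carbon and does not bear directly on what follows.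

Compound 4 `CCC(=O)N1c2ccccc2CCC1C(=O)Nc1cc(C(F)(F)F)cc(C(F)(F)F)c1` differs from compound 3 by hydrogen in place of hexyl on a saturated chain carbon, two bonds along the chain from a carbonyl carbon; the chain on that carbonyl ends up shorter than in compound 1. Going by the values given here, the one step that bears on this is the chain step from compound 1 to compound 3, which went to a lower number with a longer chain. Cutting the chain back reverses that, so compound 4 is expected to return a higher number than compound 3, in the region of compound 1 or somewhat beyond it, because a 2.5-fold lower number from compound 1 to compound 3 (0.40 log units; beyond the scatter) was modest and only one step. For compound 4 the expected step is a 3.0-fold higher number from compound 3 to compound 4 (0.47 log units; beyond the scatter). Compound 4 is estimated at 22000 nM, with a range from 8000 nM to 60000 nM.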

Compound 4, concentration for 50% growth inhibition: 8540 nM
Estimate against measurement, compound 4: 2.6-fold (0.41 log units) above; the measured number falls inside the stated range.
By their numbers in this assay, from the lowest: compounds 2, 3 and 4 (each within the scatter of the next, the first and the last beyond it); then compound 1.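

Hydrogen in place of hexyl, on a saturated chain carbon two bonds along the chain from a carbonyl carbon, gives a 1.1-fold higher number from compound 3 to compound 4 (0.06 log units; within the scatter) in this assay, so removing these carbons does not separate the pair. The single-carbon change at the same place gives a 2.2-fold lower number from compound 1 to compound 4 (0.34 log units; beyond the scatter), which means the propyl on the carbonyl carbon stands apart from both the shorter ethyl and the longer octyl, and the number does not follow chain length across these compounds. Replacing the 4-chlorophenyl on the carbonyl carbon with ethyl gives a 2.0-fold higher number from compound 2 to compound 4 (0.31 log units; beyond the scatter), a modest step.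

Open, from the compounds shown here alone, is whether a chain ending in an amine or a carboxylic acid at this place would depart from these numbers. No evidence on hand accounts for the propyl result.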